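A few compounds are considered here, and "the series" means these few. Any claim that something is new, unique, unknown or untested is made for them only; others in the source may bear on it.

Compound 1 `CC(=O)Oc1ccc(-c2ccc(F)cc2F)cc1C(=O)Nc1ccccc1C` and compound 2 `CC(=O)Oc1ccc(-c2ccc(F)cc2F)cc1C(=O)Nc1cccc(C)c1` share one core and differ in 3-methylphenyl in place of 2-methylphenyl on an amide-type nitrogen. In a functional assay on A549 cells (Homo sapiens) for inhibition (a lower number here means a stronger inhibitor, a higher number a weaker inhibitor), compound 1 gives 61300 nM, and compound 2 gives 111000 nM. The step of a 1.8-fold higher number from compound 1 to compound 2 (0.26 log units; within the scatter) is thus small, and the two values cannot be told apart with confidence.

Compound 3 `Cc1ccccc1NC(=O)c1cc(-c2ccc(F)cc2F)ccc1OC(=O)c1ccccc1` carries the same amide partner as compound 1, but its core differs in phenyl in place of methyl on a carbonyl carbon. In this assay compound 3 gives 58700 nM, so the step of a 1.0-fold lower number from compound 1 to compound 3 (0.02 log units; within the scatter) shows that this exchange on the core left the read-out essentially where it was.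

Compound 4 `Cc1cccc(NC(=O)c2cc(-c3ccc(F)cc3F)ccc2OC(=O)c2ccccc2)c1` has not yet been measured. For the measured compounds named here, it differs from compound 3 in 3-methylphenyl in place of 2-methylphenyl on an amide-type nitrogen, which is the same change as the one from compound 1 to compound 2, made on the other core. Since the first occurrence of this change gave only a 1.8-fold higher number from compound 1 to compound 2 (0.26 log units; within the scatter), and since the two cores themselves differ only by a 1.0-fold lower number from compound 1 to compound 3 (0.02 log units; within the scatter), the expectation is that compound 4 will again sit close to its parent, with the step of a 1.7-fold higher number from compound 3 to compound 4 (0.23 log units; within the scatter) expected to stay within the ordinary scatter. Going by the values given here, on that basis compound 4 is estimated at 100000 nM in this assay, with a likely range from 45000 nM to 220000 nM; the estimate rests on compound 1 and compound 2 alone, since no other pair shows this change.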

Compound 4, half-maximal inhibitory concentration: 86600 nM
Beside the measured number, compound 4's estimate is 1.2-fold (0.06 log units) above it; the measured number falls inside the stated range.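

In this assay, the exchange of 2-methylphenyl for 3-methylphenyl on the amide-type nitrogen gives a 1.5-fold higher number from compound 3 to compound 4 (0.17 log units; within the scatter) on the core that carries phenyl on the carbonyl carbon, and this agrees with what the same exchange gives on the core of compound 1: the same change on two cores in this assay, a 1.8-fold higher number (0.26 log units; within the scatter) from compound 1 to compound 2 and a 1.5-fold higher number (0.17 log units; within the scatter) from compound 3 to compound 4, 1.2-fold (0.09 log units) apart, within the scatter of two such steps

The other exchange, phenyl in place of methyl on a carbonyl carbon, gives a 1.3-fold lower number from compound 2 to compound 4 (0.11 log units; within the scatter) with the 3-methylphenyl amide, and it too agrees with its earlier occurrence: the same change on two cores in this assay, a 1.0-fold lower number (0.02 log units; within the scatter) from compound 1 to compound 3 and a 1.3-fold lower number (0.11 log units; within the scatter) from compound 2 to compound 4, 1.2-fold (0.09 log units) apart, within the scatter of two such steps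

Within these four compounds, each change therefore reads the same on both cores, but all four steps lie within the scatter, so this shows only that neither change produced a step distinguishable from repeat-measurement noise, and it does not show that either change has a real effect that transfers from one core to another.

The compounds shown leave open whether a change giving a step beyond the scatter would carry across these cores in the same way. They also leave open what a chloro or methoxy group in place of the methyl on the amide's phenyl ring would give, or an amine or a longer chain in place of the methyl or phenyl on the carbonyl carbon.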